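Swapping the amide aryl group for an amine-bearing chain

The source may hold more compounds than are shown below. What is called first, only, known or untested is meant among the compounds shown, and "the series" means these compounds.

Measured compounds:
compound 1, `O=C(CCC(=O)OCCCCCCSc1ccc([N+](=O)[O-])c2nonc12)Nc1ccccc1`, 3850 nM
compound 2, `O=C(CCC(=O)OCCCCCCSc1ccc([N+](=O)[O-])c2nonc12)Nc1ccc(F)cc1`, 2500 nM
compound 3, `Cc1ccc(NC(=O)CCC(=O)OCCCCCCSc2ccc([N+](=O)[O-])c3nonc23)cc1`, 3250 nM

Of the compounds shown here, three sharing one core have been tested in a functional assay on 143B cells (Homo sapiens) for inhibition, read by MTT assay, with a stated time of 72 h; a lower number here means a stronger inhibitor, a higher number a weaker inhibitor. Compound 1 gives the highest of the three numbers, but all three lie close together: the step of a 1.5-fold lower number from compound 1 to compound 2 (0.19 log units; within the scatter), the step of a 1.2-fold lower number from compound 1 to compound 3 (0.07 log units; within the scatter) and the step of a 1.3-fold higher number from compound 2 to compound 3 (0.11 log units; within the scatter) each stay within the scatter, so no ordering among compound 1, compound 2 and compound 3 can be claimed.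

Compound 4, `CCN(CC)CCCNC(=O)CCC(=O)OCCCCCCSc1ccc([N+](=O)[O-])c2nonc12`, is the next compound to be tested in this assay. Its difference from compound 1 is 3-(diethylamino)propyl in place of phenyl on an amide-type nitrogen. This is a change of a different kind from the ones already measured: the three known steps only exchange a small substituent on the phenyl ring, whereas here the phenyl ring itself is removed and a 3-(diethylamino)propyl chain takes its place on the amide-type nitrogen. The measured steps therefore say only that small edits to this part of compound 1 have left the number essentially unchanged; they give no direct guide to this larger replacement.

With nothing in the data pointing in either direction, compound 4 is expected to sit near compound 1, as a 1.1-fold lower number from compound 1 to compound 4 (0.04 log units; within the scatter), with a wide range to reflect the uncertainty. The estimate for compound 4 is 3500 nM, between 900 nM and 14000 nM.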

Compound 4, half-maximal inhibitory concentration: 3440 nM
Compound 4: middle estimate off by 1.0-fold (0.01 log units), on the high side; measured number inside the range.
By their numbers in this assay, from the lowest: compounds 2, 3, 4 and 1 (each within the scatter of the next).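

In this assay, removing the whole phenyl ring from the amide-type nitrogen and putting 3-(diethylamino)propyl there produces no readable change: a 1.1-fold lower number from compound 1 to compound 4 (0.05 log units; within the scatter), and the comparisons with the substituted rings agree, with a 1.1-fold higher number from compound 3 to compound 4 (0.02 log units; within the scatter) and a 1.4-fold higher number from compound 2 to compound 4 (0.14 log units; within the scatter). The earlier compounds shown here showed only that small substituents on the phenyl ring leave the number where it is, whereas these steps show that, at least for this one chain, an aromatic ring on this nitrogen is not required to keep the number in the same range. Nothing available here explains why such different groups give such similar numbers.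

From the compounds shown here alone, it remains open whether this tolerance is general, since a single ring-free group cannot show whether a plain alkyl chain without the amine, a carboxylic acid or a much bulkier amine would behave the same way. All four compounds also keep the rest of the structure unchanged, so they say nothing about how much the number depends on the shared core rather than on the group at this nitrogen.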